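The compounds below may be only part of what the source reports. "The series", "measured", "known", "first", "only" and "open" are said of these compounds alone.

In a functional assay on K562 cells (Homo sapiens) for inhibition, read by trypan blue exclusion, with a stated time of 72 h (a lower number here means a stronger inhibitor, a higher number a weaker inhibitor), compound 1 `Cc1ccc(S(=O)(=O)c2cc3cnc(Nc4cnc5[nH]ccc5c4)nc3n(C)c2=O)cc1` gives 15000 nM and compound 2 `Cc1ccc(S(=O)(=O)c2cc3cnc(Nc4ccc5ncccc5c4)nc3n(C)c2=O)cc1` gives 10000 nM. These two values lie within the scatter of each other, so compound 2 cannot be ranked against compound 1. The next change leads to compound 3 `Cc1ccc(S(=O)(=O)c2cc3cnc(Nc4cccc5[nH]ccc45)nc3n(C)c2=O)cc1`, with 1H-indol-4-yl in place of quinolin-6-yl on a nitrogen on an aromatic ring. Within the data shown here, only one measured step bears on this swap. It is a 1.5-fold lower number from compound 1 to compound 2 (0.18 log units; within the scatter), which also exchanged the group on that nitrogen and stayed within the scatter. The group entering compound 3 shares a five-membered aromatic ring with the group of compound 1, whose value is 15000 nM. One step is thin evidence, but no change beyond the scatter is expected in this assay. The expected step is a 1.2-fold higher number from compound 2 to compound 3 (0.08 log units; within the scatter). Compound 3 is estimated at 12000 nM, with an expected range of 4000 nM to 30000 nM.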

Compound 3, half-maximal inhibitory concentration: 5000 nM
Compound 3: middle estimate off by 2.4-fold (0.38 log units), on the high side, within the range that was stated.
By their numbers in this assay, from the lowest: compounds 3, 2 and 1 (each within the scatter of the next, the first and the last beyond it).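

Among these compounds, there is a 3.0-fold lower number from compound 1 to compound 3 (0.48 log units; beyond the scatter) in this assay, the first change of the group on this nitrogen to lie beyond the scatter, though it is modest. Both groups in that step hold a five-membered aromatic ring with 1 hetero atom, while 1H-indol-4-yl has a six-membered aromatic ring of carbon only where the group of compound 1 has one with 1 hetero atom. The other new result, a 2.0-fold lower number from compound 2 to compound 3 (0.30 log units; within the scatter), stays within the scatter, so 1H-indol-4-yl cannot be ranked against quinolin-6-yl; no measurement here explains either step.

On these data alone, what a plain phenyl group or a small open-chain amine would give on this nitrogen remains open. So does whether the hydrogen-bond donor counted in 1H-indol-4-yl has any part in these numbers.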